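Growth Inhibition from Compound 3 to Compound 4

The compounds below may be only part of what the source reports. "The series", "measured", "known", "first", "only" and "open" are said of these compounds alone.

Values measured in a functional assay on A549 cells (Homo sapiens) for inhibition, read by CCK-8 assay, with a stated time of 72 h, tested at 10 uM; on this read-out lower numbers stand for less inhibition of growth and higher numbers for more inhibition of growth at the one concentration tested:
- compound 1 `Cc1cccc(NC(=O)C2(C(=O)Nc3ccc(Nc4ncc5cc(C(=O)N(C)C)n(C6CCCC6)c5n4)cc3)CC2)c1`: 86.1%
- compound 2 `COc1ccc(NC(=O)C2(C(=O)Nc3ccc(Nc4ncc5cc(C(=O)N(C)C)n(C6CCCC6)c5n4)cc3)CC2)cc1`: 78.5%
- compound 3 `CN(C)C(=O)c1cc2cnc(Nc3ccc(NC(=O)C4(C(=O)Nc5cccc(Cl)c5)CC4)cc3)nc2n1C1CCCC1`: 90.7%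

Compound 3 has the top number of the three at 90.7%, but it cannot be separated from compound 1. The step of a number 4.6 percentage points higher from compound 1 to compound 3 (within the scatter) lies within the scatter. Only compound 2 falls clearly short, with a number 12.2 percentage points higher from compound 2 to compound 3 (beyond the scatter) beyond the scatter, and that step is modest.

The next compound, compound 4 `CN(C)C(=O)c1cc2cnc(Nc3ccc(NC(=O)C4(C(=O)Nc5ccc(Cl)c(C(F)(F)F)c5)CC4)cc3)nc2n1C1CCCC1`, carries 4-chloro-3-(trifluoromethyl)phenyl in place of 3-chlorophenyl on an amide-type nitrogen. The three measured steps all concern the same aromatic group. Besides the two above, the step of a number 7.6 percentage points lower from compound 1 to compound 2 (within the scatter) also stays within the scatter. Changes to this group have therefore moved the read-out only slightly, though none of them tested a trifluoromethyl group, so the data offer no direct precedent. Compound 3 at 90.7% also leaves limited room for any rise.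

No step beyond the scatter is expected in this assay, and the expected change is a number 1.7 percentage points lower from compound 3 to compound 4 (within the scatter). For compound 4 the estimated value is 89%, with an expected range from 77% to 98%.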

Compound 4, percent growth inhibition at one concentration: 88.1%
Compound 4: middle estimate off by 0.9 percentage points, on the high side; measured number inside the range.
By their numbers in this assay, from the lowest: compounds 2, 1, 4 and 3 (each within the scatter of the next, the first and the last beyond it).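

In this assay, going by these compounds alone, the amide-type nitrogen carries a trifluoromethyl group for the first time, and the larger 4-chloro-3-(trifluoromethyl)phenyl group, at 11 heavy atoms against 7 for 3-chlorophenyl, still leaves the read-out unresolved from that of its closest comparators (a number 2.6 percentage points lower from compound 3 to compound 4 (within the scatter); a number 2 percentage points higher from compound 1 to compound 4 (within the scatter)). The comparison with the 4-methoxyphenyl group adds a further point (a number 9.6 percentage points higher from compound 2 to compound 4 (within the scatter)): compound 3 stood clearly apart from compound 2, whereas compound 4 does not, so the one clear step among these groups is not shared by the newest group. No measured evidence bears on why this position tolerates such different groups with so little movement in the read-out.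

Going by these compounds, it remains open whether this tolerance would extend to an amine or a carboxylic acid on the phenyl group, or to a longer chain in place of the trifluoromethyl group. On these data alone, with every number taken at one concentration, it also remains open whether compound 1, compound 3 and compound 4 would stay together across a range of concentrations.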